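The source may report more compounds than this note shows. Statements on the series, on what has been measured and on what is new or still open speak of the compounds shown alone.

Going by the values given here, compound 2 `CCN(CC)S(=O)(=O)c1ccc(S(=O)(=O)N2CCC[C@@H](C(=O)N[C@@H]3CCOC3)C2)cc1` gives the lower of the two numbers measured so far in a functional assay on BXPC-3 cells (Homo sapiens) for inhibition, read by MTT assay, with a stated time of 7 days; a higher number here means a weaker inhibitor, a lower number a stronger inhibitor: compound 2 gives 2270 nM, while compound 1 `CCN(CC)S(=O)(=O)c1ccc(S(=O)(=O)N2CCC[C@@H](C(=O)NC3CCOCC3)C2)cc1` gives 8570 nM. Among the compounds with values here, the only step measured is a 3.8-fold lower number from compound 1 to compound 2 (0.58 log units; beyond the scatter). Compound 3 `CCN(CC)S(=O)(=O)c1ccc(S(=O)(=O)N2CCC[C@@H](C(=O)N3CC[C@@H](OC)C3)C2)cc1` differs from compound 2 by 3-methoxypyrrolidin-1-yl in place of (oxolan-3-yl)amino on a carbonyl carbon. Within the data shown here, no measured step touches an amide nitrogen in this way, so the earlier step offers little guidance. Because of a 3.8-fold lower number from compound 1 to compound 2 (0.58 log units; beyond the scatter) the five-membered ring is kept; the estimate for compound 3 in this assay is 3500 nM (range 1200 nM to 12000 nM), and the expected step is a 1.5-fold higher number from compound 2 to compound 3 (0.19 log units; within the scatter).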

Compound 3, half-maximal inhibitory concentration: 11500 nM
Compound 3: the middle estimate sits 3.3-fold (0.52 log units) below what was measured; measured number inside the range.
By their numbers in this assay, from the lowest: compound 2; then compounds 1 and 3 (each within the scatter of the next).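

In this assay, 3-methoxypyrrolidin-1-yl in place of (oxolan-3-yl)amino on the carbonyl carbon gives a 5.1-fold higher number from compound 2 to compound 3 (0.70 log units; beyond the scatter), so a five-membered ring alone does not keep the lower number. Set against (oxan-4-yl)amino, the same group gives a 1.3-fold higher number from compound 1 to compound 3 (0.13 log units; within the scatter), which leaves the advantage of oxolan-3-yl lost. The entering group has 0 hydrogen-bond donors where the leaving group has 1, but no measurement here explains the step. Open, on these data alone, is whether the amide hydrogen or the methoxy group matters more. A methyl on the amide nitrogen of compound 2, or a plain pyrrolidin-1-yl, would separate the two.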